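From Chloro to Fluoro on the Shared Core

The source may report more compounds than this note shows. Statements on the series, on what has been measured and on what is new or still open speak of the compounds shown alone.

In an ADME assay on Vero cells (Chlorocebus sabaeus) for inhibition (on this read-out higher numbers stand for lower toxicity in this test and lower numbers for higher toxicity in this test), compound 1 `COc1ccc(/C=C2\CCC/C(=C\c3ccccc3)C2=O)cc1` gives 291000 nM, compound 2 `COc1ccc(/C=C2\CCC/C(=C\c3ccc(N(C)C)cc3)C2=O)cc1` gives 392000 nM, and compound 3 `COc1ccc(/C=C2\CCC/C(=C\c3ccc(Cl)cc3)C2=O)cc1` gives 401000 nM. These three numbers lie within the scatter of one another, so compound 3 stands level with the other two and not apart from them.

Compound 4 `COc1ccc(/C=C2\CCC/C(=C\c3ccc(F)cc3)C2=O)cc1` has not yet been measured. It differs from compound 3 by a single change, (fluoro in place of chloro on an aromatic carbon), which is fluoro in place of chloro on an aromatic carbon. Among the compounds with values here, three measured steps bear on this change, each a swap on an aromatic carbon: a 1.4-fold higher number from compound 1 to compound 3 (0.14 log units; within the scatter), a 1.3-fold higher number from compound 1 to compound 2 (0.13 log units; within the scatter) and a 1.0-fold higher number from compound 2 to compound 3 (0.01 log units; within the scatter). All three stay within the scatter, so no step beyond the scatter is expected in this assay, and no direction can be relied on. The expected step is a 1.1-fold lower number from compound 3 to compound 4 (0.06 log units; within the scatter), which is within the scatter. The estimate for compound 4 is 350000 nM, with an expected range of 220000 nM to 550000 nM.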

Compound 4, half-maximal cytotoxic concentration: 378000 nM
Estimate against measurement, compound 4: 1.1-fold (0.03 log units) below, within the range that was stated.
By their numbers in this assay, from the lowest: compounds 1, 4, 2 and 3 (each within the scatter of the next).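

In this assay, fluoro in place of chloro at this position, on an aromatic carbon para to a large group, comes to a 1.1-fold lower number from compound 3 to compound 4 (0.03 log units; within the scatter) and so does not separate the two compounds on this read-out. Set against the other two groups, fluoro gives the same picture: a 1.0-fold lower number from compound 2 to compound 4 (0.02 log units; within the scatter) and a 1.3-fold higher number from compound 1 to compound 4 (0.11 log units; within the scatter) leave hydrogen, chloro, dimethylamino and fluoro at this place all within the scatter of one another. Nothing available offers an explanation for how closely these four compounds sit.

As far as these compounds go, whether a carboxylic acid, a primary amine or a longer chain such as butoxy at this place would move the number beyond the scatter remains open. Also open, from the compounds shown here alone, is whether a hydroxy group in place of the methoxy group on the shared core would do so.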